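Compound 3 to compound 4: closing the chain into a ring

This account rests on a few compounds, and the source may have more. Where it says the series, first, only, none or still open, it means among the compounds named here.

In a physicochemical assay for solubility, at pH 7.4 (on this read-out higher numbers stand for higher solubility and lower numbers for lower solubility), compound 3 `CCC(C)(C#N)Nc1nc(NC)nc(-n2cncn2)n1` gives 50 ug/mL, within the scatter of compound 1 `CCCC(C#N)(CC)Nc1nc(NC)nc(-n2cncn2)n1` at 76 ug/mL, while compound 2 `CNc1nc(NC2(C#N)CCCCC2)nc(-n2cncn2)n1` gives 11 ug/mL, beyond the scatter from compound 3. The change to compound 4 `CNc1nc(NC2(C#N)CCCC2)nc(-n2cncn2)n1` is 1-cyanocyclopentyl in place of 1-cyano-1-methylpropyl on a nitrogen on an aromatic ring. Within the data shown here, the only measured single-place step, a 1.5-fold lower number from compound 1 to compound 3 (0.18 log units; within the scatter), stays on the open chain and says little about a ring. Among the measured compounds shown here, the closest guide is compound 2 at 11 ug/mL, the only measured compound with a non-aromatic ring of carbon only. A lower number in this assay is therefore expected, near the edge of the scatter. The expected step is a 2.0-fold lower number from compound 3 to compound 4 (0.30 log units; within the scatter). Compound 4 is estimated at 25 ug/mL, with an expected range of 11 ug/mL to 55 ug/mL.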

Compound 4, solubility: 165 ug/mL
Beside the measured number, compound 4's estimate is 6.6-fold (0.82 log units) below it, and the stated range ends below it.
By their numbers in this assay, from the lowest: compound 2; then compounds 3 and 1 (each within the scatter of the next); then compound 4.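

Among these compounds, with a 3.3-fold higher number from compound 3 to compound 4 (0.52 log units; beyond the scatter) in this assay the 1-cyanocyclopentyl group gives the first step beyond the scatter at this position on the nitrogen. Compound 2 also carries a non-aromatic ring of carbon only there and gives 11 ug/mL in this assay, so a ring alone does not settle the number. Nothing measured here accounts for the rise.

Still open, on these data alone, is whether cyclobutyl follows compound 4 or compound 2. Also open, as far as these compounds go, is whether a ring holding an oxygen or an amine nitrogen keeps the higher number.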